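The source may report more compounds than this note shows. Statements on the series, on what has been measured and on what is new or still open speak of the compounds shown alone.

Measured compounds:
compound 1 `Cn1nc(C(F)(F)F)cc1C(=O)Nc1ccc(S(=O)(=O)N2CCCCC2)cc1` — > 300000 nM
compound 2 `Cn1nc(C(F)(F)F)cc1C(=O)Nc1ccc(S(=O)(=O)N2CCC[C@H]2C(=O)O)cc1` — > 300000 nM
compound 3 `Cn1nc(C(F)(F)F)cc1C(=O)Nc1ccc(S(=O)(=O)N2CCOCC2)cc1` — > 300000 nM

In an ADME assay on Vero cells (Chlorocebus sabaeus) for cytotoxicity, read by MTT assay (a higher number here means that more compound is tolerated, a lower number that less compound is tolerated), compound 1 gives > 300000 nM, which is a limit of the assay and not a number. Compound 2 likewise gives only a limit, > 300000 nM. Compound 3 also gives only a limit, > 300000 nM. The steps among them are therefore not readable: a step that the two limits leave unreadable from compound 1 to compound 2, a step that the two limits leave unreadable from compound 1 to compound 3 and a step that the two limits leave unreadable from compound 2 to compound 3. All three values sit at the same point, (the limit of > 300000 nM in this assay, at which 3 of the 3 values shown sit), so compound 1 stands at a limit with no numbered neighbour.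

Compound 4 `Cn1nc(C(F)(F)F)cc1C(=O)Nc1ccc(S(=O)(=O)N2CCCCC2C(=O)O)cc1` differs from compound 1 by carboxy in place of hydrogen on a saturated ring carbon. The closest measured step, a step that the two limits leave unreadable from compound 1 to compound 2, also introduces a carboxy on the ring at the sulfonyl sulfur and is unreadable, so no size and no direction beyond the scatter can be taken from it. Compound 4 is expected to remain at the limit, with an estimate of 300000 nM and a range from 150000 nM to 1000000 nM. The expected step is a number no higher from compound 1 to compound 4 (the limit leaves the size open), that is, none readable.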

Compound 4, half-maximal cytotoxic concentration: > 300000 nM
Compound 4: only a limit was reported; the forecaster's own chance of this, stated with the estimate: 90%; the middle value sits exactly at the limit.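

In this assay, going by these compounds alone, compound 4 gives > 300000 nM, a limit and not a number, so no step from compound 1, compound 2 or compound 3 to compound 4 can be read. The compounds shown carry no numbered value, which leaves open whether any group on the sulfonyl sulfur changes the tolerated concentration.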